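Series notes: three measured compounds and an estimate for compound 4

A few compounds are considered here, and "the series" means these few. Any claim that something is new, unique, unknown or untested is made for them only; others in the source may bear on it.

Values in an ADME assay on LLC-PK1 cells (Sus scrofa) for cytotoxicity, read by neutral red uptake; on this read-out lower numbers stand for stronger inhibition and higher numbers for weaker inhibition:
compound 1 `COC(/C=C/c1ccccc1)=C1\C(=O)C=C(C)C1=O`: 3.4 ug/mL
compound 2 `COC(/C=C/c1ccco1)=C1\C(=O)C=C(C)C1=O`: 3.3 ug/mL
compound 3 `CC(=O)OC(/C=C/c1ccccc1)=C1\C(=O)C=C(C)C1=O`: 4.9 ug/mL

Compound 1 sits within the scatter of both other numbers in this assay: a 1.0-fold lower number from compound 1 to compound 2 (0.01 log units; within the scatter), and a 1.4-fold higher number from compound 1 to compound 3 (0.16 log units; within the scatter). Neither the swap of the aromatic group on the chain nor the swap on the oxygen moved the read-out beyond what repeated measurements give.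

Compound 4 `COC(/C=C/c1ccc(OC)cc1)=C1\C(=O)C=C(C)C1=O` has not been measured. It differs from compound 1 by methoxy in place of hydrogen on an aromatic carbon, the new group sitting on an aromatic carbon of a six-membered aromatic ring of carbon only. Within the data shown here, no measured step places a substituent on that ring, so the expectation rests on the two steps above, both within the scatter, and on the closeness of all three numbers. The expected step in this assay is a 1.1-fold higher number from compound 1 to compound 4 (0.02 log units; within the scatter), in no preferred direction. Compound 4 is therefore estimated at 3.6 ug/mL, with a range from 1.8 ug/mL to 7.5 ug/mL.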

Compound 4, half-maximal inhibitory concentration: 3.9 ug/mL
Estimate against measurement, compound 4: 1.1-fold (0.03 log units) below, and the stated range covers the measured number.
By their numbers in this assay, from the lowest: compounds 2, 1, 4 and 3 (each within the scatter of the next).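

In this assay, among these compounds, the step for methoxy in place of hydrogen is a 1.1-fold higher number from compound 1 to compound 4 (0.06 log units; within the scatter), and it is the first to put a substituent on the six-membered aromatic ring rather than exchange the ring itself or the group on the oxygen. The ring of compound 1 therefore accepts methoxy at this one place, para to a large group, with the number staying within the scatter. No measurement shown accounts for this result.

From the compounds shown here alone, whether an amine or a carboxylic acid at the same place would also stay within the scatter remains open. The compounds shown also pair methoxy on the ring only with methyl on the oxygen, so its step alongside the acetyl of compound 3 is unknown.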